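This account rests on a few compounds, and the source may have more. Where it says the series, first, only, none or still open, it means among the compounds named here.

In an ADME assay on HEK-293T cells (Homo sapiens) for cytotoxicity, read by CCK-8 assay, with a stated time of 48 h (on this read-out higher numbers stand for weaker inhibition and lower numbers for stronger inhibition), compound 2 `O=S(=O)(NCCNC(=S)Nc1cccc(Cl)c1)c1ccc(-c2ccccc2OCc2ccccc2)s1` gives 10200 nM and compound 3 `O=[N+]([O-])c1cccc(NC(=S)NCCNS(=O)(=O)c2ccc(-c3ccccc3OCc3ccccc3)s2)c1` gives 18300 nM, two numbers within the scatter of each other, with a 1.8-fold higher number from compound 2 to compound 3 (0.25 log units; within the scatter). Compound 1 `COc1ccc(NC(=O)NCCNS(=O)(=O)c2ccc(-c3ccccc3OCc3ccccc3)s2)cc1` gives only a limit, > 50000 nM. Compound 4 `O=C(NCCNS(=O)(=O)c1ccc(-c2ccccc2OCc2ccccc2)s1)Nc1cccc([N+](=O)[O-])c1` differs from compound 3 by a group of 12 heavy atoms (7 carbon, 2 nitrogen, 3 oxygen; one six-membered aromatic ring of carbon only) in place of a group of 12 heavy atoms (7 carbon, 2 nitrogen, 2 oxygen, 1 sulfur; one six-membered aromatic ring of carbon only), on an amine nitrogen, with (3-nitrophenyl)carbamoyl as the entering group. The nearest guide is an at least 2.7-fold lower number from compound 1 to compound 3 (0.43 log units; beyond the scatter), and an at least 4.9-fold lower number from compound 1 to compound 2 (0.69 log units; beyond the scatter) runs the same way, both beyond the scatter. Each of these steps changes more than the exchange at issue here, so they bear on it only in part. A modest rise is therefore expected in this assay, an estimated 2.2-fold higher number from compound 3 to compound 4 (0.34 log units; beyond the scatter). Compound 4 is expected at 40000 nM, with an estimated range from 20000 nM to 80000 nM.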

Compound 4, half-maximal inhibitory concentration: 13300 nM
The estimate for compound 4 lay 3.0-fold (0.48 log units) above the measured number; the measured number lies below the stated range.
By their numbers in this assay, from the lowest: compounds 2, 4 and 3 (each within the scatter of the next). At a limit, above all of these: compound 1.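

In this assay, (3-nitrophenyl)carbamoyl on the amine nitrogen, with oxygen where compound 3 carries sulfur, leaves the number within the scatter: a 1.4-fold lower number from compound 3 to compound 4 (0.14 log units; within the scatter). Compound 4 also stays within the scatter of the chloro compound, a 1.3-fold higher number from compound 2 to compound 4 (0.12 log units; within the scatter). With the sulfur exchange out of the comparison, 3-nitrophenyl in place of 4-methoxyphenyl on an amide-type nitrogen alone gives an at least 3.7-fold lower number from compound 1 to compound 4 (0.57 log units; beyond the scatter), a step read from a limit: the limit of > 50000 nM in this assay, at which 1 of the 4 values shown sits.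

On these data alone, the true size of that step stays open. So does whether a carboxylic acid or an amine on the aromatic ring, or a longer chain on the amine nitrogen, would keep the number in this range.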